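The source may report more compounds than this note shows. Statements on the series, on what has been measured and on what is new or still open speak of the compounds shown alone.

Measured so far:
- compound 1, `O=C(/C=C/c1ccc(Br)cc1)NS(=O)(=O)c1ccc(Br)cc1`, with 5.1 ug/mL in a functional assay on B16-F10 cells (Mus musculus) for antiproliferative activity, read by ELISA and MTT assay, with a stated time of 48 h; on this read-out lower numbers stand for stronger inhibition and higher numbers for weaker inhibition
- compound 2, `COc1ccc(/C=C/C(=O)NS(=O)(=O)c2ccccc2)cc1`, with 13.2 ug/mL in this assay

Both compounds were tested in this assay. Of the two numbers, compound 2 has the higher one; its nearest neighbour is compound 1, whose number is lower by a gap that goes beyond the usual scatter of the measurement. Compound 1 and compound 2 differ in more than one place, so the two values alone cannot be tied to a single change.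

The next compound, compound 3, is `COc1ccc(/C=C/C(=O)NS(=O)(=O)c2ccc(Br)cc2)cc1`. It differs from compound 2 in one place: bromo in place of hydrogen on an aromatic carbon. For the measured compounds named here, no measured pair shows this exact change on its own. Since compound 1, which carries bromine on the same kind of ring, gives 5.1 ug/mL, a step toward a lower number is expected, of modest size, a 1.7-fold lower number from compound 2 to compound 3 (0.22 log units; within the scatter). Compound 3 is therefore expected to give about 8 ug/mL, within a range from 4 ug/mL to 16 ug/mL.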

Compound 3, half-maximal inhibitory concentration: 5.8 ug/mL
Compound 3: middle estimate off by 1.4-fold (0.14 log units), on the high side, within the range that was stated.
By their numbers in this assay, from the lowest: compounds 1 and 3 (each within the scatter of the next); then compound 2.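

For the compounds shown here, changing phenyl to 4-bromophenyl gives a 2.3-fold lower number from compound 2 to compound 3 (0.36 log units; beyond the scatter) in this assay and lies beyond the scatter, so this is the first single change that can be read on its own, and it points toward stronger inhibition. Methoxy in place of bromo on an aromatic carbon gives a 1.1-fold higher number from compound 1 to compound 3 (0.06 log units; within the scatter) and stays within the scatter, so these two compounds cannot be told apart here, and that place tolerates either group in this assay. Nothing available explains either step.

On these data alone, it remains open whether chloro, an amine or a carboxylic acid in place of the bromo of 4-bromophenyl would give a lower or a higher number. As far as these compounds go, it also remains open whether the step seen with bromo would hold if the methoxy were replaced by a longer chain.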